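Swapping Fluoro for Methyl on the Fused Ring

The source may report more compounds than this note shows. Statements on the series, on what has been measured and on what is new or still open speak of the compounds shown alone.

Two members of this series have been measured in a functional assay on NCI-H460 cells (Homo sapiens) for inhibition, read by MTT assay, with a stated time of 72 h; a higher number here means a weaker inhibitor, a lower number a stronger inhibitor. Compound 1 `Cc1ccc2c(c1)/C(=c1/sc(=Cc3ccc(C=O)c(C=O)c3)c(=O)n1CCN(C)C)C(=O)N2` gives 4030 nM in this assay. Compound 2 `CN(C)CCn1c(=O)c(=Cc2ccc(F)c(F)c2)s/c1=C1\C(=O)Nc2ccc(F)cc21` gives 44700 nM in this assay, the higher of the two numbers and therefore the weaker inhibitor of the pair; the gap between compound 2 and compound 1 is beyond the usual scatter. Compound 3 `Cc1ccc2c(c1)/C(=c1/sc(=Cc3ccc(F)c(F)c3)c(=O)n1CCN(C)C)C(=O)N2` has not yet been measured. It differs from compound 2 in one place: methyl in place of fluoro on an aromatic carbon. Compound 1 carries the same methyl on its core, but it also carries a different group on the other ring, so the two measured numbers cannot be split between the two changes. For compound 3 the step expected from compound 2 is a 2.2-fold lower number from compound 2 to compound 3 (0.35 log units; beyond the scatter), a modest move toward stronger inhibition with wide uncertainty. Compound 3 is estimated at 20000 nM in this assay, within 6000 nM to 60000 nM.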

Compound 3, half-maximal inhibitory concentration: 59700 nM
Estimate against measurement, compound 3: 3.0-fold (0.47 log units) below, and the stated range covers the measured number.
By their numbers in this assay, from the lowest: compound 1; then compounds 2 and 3 (each within the scatter of the next).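

On the fused ring, methyl in place of fluoro gives a 1.3-fold higher number from compound 2 to compound 3 (0.13 log units; within the scatter) in this assay, so at this aromatic carbon the two groups cannot be told apart in this assay. With the methyl held in common, the other ring can now be read alone: 3,4-difluorophenyl in place of 3,4-diformylphenyl gives a 15-fold higher number from compound 1 to compound 3 (1.17 log units; beyond the scatter), and so the large difference among these compounds goes with that ring and not with the fluoro-to-methyl swap. Nothing measured here explains either result.

Still open, going by these compounds, is whether a larger or differently built group at the same carbon, such as an amine or a carboxylic acid, would separate from methyl and fluoro. Also open, on these data alone, is whether 3,4-diformylphenyl would hold its edge over 3,4-difluorophenyl with fluoro rather than methyl on the fused ring.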